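The source may hold more compounds than are shown below. What is called first, only, known or untested is meant among the compounds shown, and "the series" means these compounds.

Compound 1 `CC(C)(C)OC(=O)N1CCC(Oc2cccc3c2CCN3c2ccc(S(C)(=O)=O)cc2)CC1` gives 158 nM in a functional assay on CHO-K1 cells for agonist activity at Glucose-dependent insulinotropic receptor (Homo sapiens), read by a luciferase reporter, with a stated time of 5 h; a higher number here means that more compound is needed for the effect, a lower number that less compound is needed. Compound 2 `CC(C)(C)OC(=O)N1CCC(Oc2ncnc3c2CCN3c2ccc(S(C)(=O)=O)cc2F)CC1`, in this assay, gives 20 nM, the lower of the two numbers, and compound 1 sits beyond the scatter at the higher one. Compound 3 `CCCCOC(=O)N1CCC(Oc2ncnc3c2CCN3c2ccc(S(C)(=O)=O)cc2F)CC1` has not been measured; it differs from compound 2 by butyl in place of tert-butyl on an oxygen next to a carbonyl group. Within the data shown here, no measured pair shows this change, so its size cannot be set from the data; a step toward a higher number, within or only modestly beyond the scatter, is what is expected. For compound 3 in this assay the expected value is 40 nM, within 10 nM to 160 nM. That estimate means an expected step of a 2.0-fold higher number from compound 2 to compound 3 (0.30 log units; within the scatter).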

Compound 3, half-maximal effective concentration: 50.1 nM
Estimate against measurement, compound 3: 1.3-fold (0.10 log units) below; the range from low to high includes it.
By their numbers in this assay, from the lowest: compound 2; then compound 3; then compound 1.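

In this assay, replacing tert-butyl with butyl on an oxygen next to a carbonyl group gives a 2.5-fold higher number from compound 2 to compound 3 (0.40 log units; beyond the scatter). Among these compounds, this is the first pair that differs at this place alone, and since the two groups have the same four carbons, it shows that the number responds to how those carbons are joined, not only to how many there are. Nothing measured here accounts for the step. On these data alone, whether a longer chain such as hexyl, a ring such as cyclobutyl, or an amine in place of the oxygen would move the number further remains open. So does whether this step would hold on a different core.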